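The source may hold more compounds than are shown below. What is called first, only, known or untested is meant among the compounds shown, and "the series" means these compounds.

Measured compounds:
compound 1, `NC(=S)N/N=C1/C=C(Nc2cccc(Cl)c2)C(Nc2cccc(Cl)c2)=NC1=O`: 2190 nM
compound 2, `Cc1ccccc1NC1=C/C(=N/N=C(\N)SCc2ccccc2)C(=O)N=C1Nc1ccccc1C`: 17100 nM

Both compounds were tested in a functional assay on Bel-7402 cells (Homo sapiens) for antiproliferative activity, read by MTT assay, with a stated time of 72 h; a higher number here means a weaker inhibitor, a lower number a stronger inhibitor. Of the two numbers, compound 1 gives the lower one, so it is the stronger inhibitor here; compound 2 gives the higher one, and the gap between the two lies beyond the scatter of this assay.

Compound 3, `N/C(=N\N=C1\C=C(Nc2cccc(Cl)c2)C(Nc2cccc(Cl)c2)=NC1=O)SCc1ccccc1`, has not yet been measured. It is derived from compound 1 by a single change: a group of 11 heavy atoms (8 carbon, 2 nitrogen, 1 sulfur; one six-membered aromatic ring of carbon only) in place of a group of 4 heavy atoms (1 carbon, 2 nitrogen, 1 sulfur; no ring), on a double-bonded nitrogen. Compound 2 carries that same larger group, but it also differs from compound 1 in the groups attached to the shared core, so its number cannot be read as a clean step from compound 1 to compound 3. It is still the only hint available, and it points toward a weaker inhibitor.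

Compound 3 is therefore expected to give 6000 nM, with a range from 2000 nM to 20000 nM. This estimate means an expected step of a 2.7-fold higher number from compound 1 to compound 3 (0.44 log units; beyond the scatter) toward a higher number, that is, weaker inhibition, because compound 2 gives 17100 nM while sharing the entering group.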

Compound 3, half-maximal inhibitory concentration: 7160 nM
The estimate for compound 3 lay 1.2-fold (0.08 log units) below the measured number; low and high end bracket the measured number.
By their numbers in this assay, from the lowest: compound 1; then compound 3; then compound 2.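

In this assay, the earlier comparison could not isolate this change, since compound 2 also differs from compound 1 in the groups attached to the shared core; a pair differing in one place now gives a 3.3-fold higher number from compound 1 to compound 3 (0.51 log units; beyond the scatter). On this double-bonded nitrogen, the larger group with its six-membered aromatic ring therefore weakens inhibition compared with the smaller group without a ring, yet compound 3 still gives a number in the micromolar range, 7160 nM. This one step changes the size, the ring and the hydrogen-bond donor and acceptor counts together, so it cannot separate them, and no measurement at hand explains the rise.

As far as these compounds go, it remains open which part of the larger group drives the step, for instance whether a methyl or a longer carbon chain in place of the aromatic ring would give a number closer to that of compound 1. It is also open whether the same change would have a similar effect on compound 2, whose partner carrying the smaller group is not among the compounds shown here.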